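The source may hold more compounds than are shown below. What is called first, only, known or untested is meant among the compounds shown, and "the series" means these compounds.

Among the compounds with values here, in a functional assay on MDA-MB-231 cells (Homo sapiens) for cytotoxicity, read by MTT assay, with a stated time of 72 h (on this read-out lower numbers stand for stronger inhibition and higher numbers for weaker inhibition), compound 1 `Nc1ccccc1NC(=O)c1ccc(NC(=S)NCc2cccc(F)c2)cc1` gives 74000 nM and compound 2 `Nc1ccccc1NC(=O)c1ccc(NC(=S)NCc2ccc(Cl)nc2)cc1` gives 42000 nM, so compound 2 stands within the usual scatter of the only other measured number. Compound 3 `Nc1ccccc1NC(=O)c1ccc(NC(=S)NCc2ccccc2F)cc1` carries 2-fluorophenyl in place of 6-chloropyridin-3-yl on a saturated chain carbon bound to an amide-type nitrogen. Within the data shown here, the one measured step that bears on this, a 1.8-fold lower number from compound 1 to compound 2 (0.25 log units; within the scatter), exchanged 3-fluorophenyl and 6-chloropyridin-3-yl at that same place and stayed within the scatter. The expected step in this assay is therefore a 1.4-fold higher number from compound 2 to compound 3 (0.15 log units; within the scatter), again no larger than the scatter. For compound 3 the estimated value is 60000 nM, with an expected range of 25000 nM to 130000 nM.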

Compound 3, half-maximal inhibitory concentration: > 100000 nM
Compound 3 was reported as a limit; the forecaster's own chance of this, stated with the estimate: 10%; middle value at least 1.6-fold (0.22 log units) away from the limit.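

Within the data shown here, at this place, on a saturated chain carbon bound to an amide-type nitrogen, 2-fluorophenyl in place of 6-chloropyridin-3-yl gives the first step beyond the scatter: an at least 2.3-fold higher number from compound 2 to compound 3 (0.37 log units; beyond the scatter). Against 3-fluorophenyl, the same group gives an at least 1.3-fold higher number from compound 1 to compound 3 (0.13 log units; that floor lies within the scatter), so the two fluorophenyl compounds cannot be told apart. In this assay compound 3 gives > 100000 nM, which is a limit of the assay and not a number, so both steps are only floors: the limit of > 100000 nM in this assay, at which 1 of the 3 values shown sits.

As far as these compounds go, the true value of compound 3 stays open. So does whether an amine or a methoxy group on this aromatic ring, or a longer chain at this place, would lower the number.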